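Trimming the Sulfur Side Chain of Compound 1

The source may report more compounds than this note shows. Statements on the series, on what has been measured and on what is new or still open speak of the compounds shown alone.

Compound 1 `Cc1cc(Nc2cc(-c3ccccc3)[nH]n2)n2nc(SCC(=O)c3ccccc3)nc2n1` is one of three related compounds tested in a functional assay on MCF7 cells (Homo sapiens) for inhibition, read by MTT assay, with a stated time of 72 h (on this read-out higher numbers stand for weaker inhibition and lower numbers for stronger inhibition), where compound 1 gives 5240 nM. That is the highest number of the three, though its gap to compound 2 `Cc1cc(Nc2ccn(Cc3ccc(F)cc3)n2)n2nc(SCc3ccc(Br)cc3)nc2n1`, which gives 4280 nM, lies within the scatter. Compound 3 `Cc1cc(Nc2ccn(Cc3nc(C)c4ccccc4n3)n2)n2nc(SCc3ccc(Br)cc3)nc2n1` gives 1430 nM; the step of a 3.0-fold lower number from compound 2 to compound 3 (0.48 log units; beyond the scatter) comes from replacing the group on a saturated chain carbon bound to an aromatic nitrogen.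

Compound 4 `CCCSc1nc2nc(C)cc(Nc3cc(-c4ccccc4)[nH]n3)n2n1` differs from compound 1 in one place: ethyl in place of benzoyl on a saturated chain carbon bound to a sulfur. Cut one bond further out, the change reads benzoylmethylsulfanyl to propylsulfanyl. Within the data shown here, no measured step touches this part of the shared core; the single measured step concerns a different position, so it gives no direct guide, and the expectation rests on compound 1 alone. Because compound 1 gives 5240 nM, compound 4 is expected to give 7000 nM, with a range from 2500 nM to 20000 nM. This estimate means an expected step of a 1.3-fold higher number from compound 1 to compound 4 (0.13 log units; within the scatter), which is not expected to exceed the scatter in either direction.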

Compound 4, half-maximal inhibitory concentration: > 50000 nM
Compound 4 was reported as a limit (the forecaster's own chance of this, stated with the estimate: 10%); middle value at least 7.1-fold (0.85 log units) from the limit.
By their numbers in this assay, from the lowest: compound 3; then compounds 2 and 1 (each within the scatter of the next). At a limit, above all of these: compound 4.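

Swapping benzoyl for ethyl on the saturated chain carbon bound to a sulfur gives an at least 9.5-fold higher number from compound 1 to compound 4 (0.97 log units; beyond the scatter) in this assay. Among these compounds, the one earlier step concerned a different position, so this is the first sign that the sulfur side chain of compound 1 matters in this assay, and that this change goes towards weaker inhibition. The value of compound 4, > 50000 nM, is a limit and not a number, so this step has no exact size: the limit of > 50000 nM in this assay, at which 1 of the 4 values shown sits.

The aromatic ring and the carbonyl of benzoyl leave together, and the compounds shown cannot tell which of the two carries the difference. A 2-oxopropyl chain, which keeps the carbonyl without the ring, or a 2-phenylethyl chain, which keeps the ring without the carbonyl, would separate the two.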